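Cyano on the benzyl of compound 3: an estimate

The compounds below may be only part of what the source reports. "The series", "measured", "known", "first", "only" and "open" are said of these compounds alone.

Measured so far:
compound 1, `COc1ccc2nccc(C3CN(C4CCN(Cc5cc6ccccc6[nH]5)CC4)C(=O)O3)c2c1`: 25.1 nM
compound 2, `COc1ccc2nccc(C3CN(C4CCN(Cc5ccc6ccccc6c5)CC4)C(=O)O3)c2c1`: 1260 nM
compound 3, `COc1ccc2nccc(C3CN(C4CCN(Cc5ccccc5)CC4)C(=O)O3)c2c1`: 12600 nM

In an in vitro functional assay on RBL cells for antagonist activity at C-C chemokine receptor type 8 (Homo sapiens), read by FLIPR and calcium flux (a lower number here means a stronger inhibitor, a higher number a weaker inhibitor), compound 3 stands with the highest number of the three, with a 10-fold higher number from compound 2 to compound 3 (1.00 log units; beyond the scatter) and a 500-fold higher number from compound 1 to compound 3 (2.70 log units; beyond the scatter). Compound 4, `COc1ccc2nccc(C3CN(C4CCN(Cc5ccc(C#N)cc5)CC4)C(=O)O3)c2c1`, differs from compound 3 by cyano in place of hydrogen on an aromatic carbon. Going by the values given here, no measured step changes a substituent on the phenyl; the measured steps replace the whole ring with a bicyclic one, and those were large, as in a 50-fold higher number from compound 1 to compound 2 (1.70 log units; beyond the scatter) and the two steps ending at compound 3. Among the compounds with values here, the change to compound 4 is smaller than any of those, and no measured pair tells how a cyano group behaves here. The step to compound 4 is therefore expected to be modest, if anything toward a lower number, as a 2.0-fold lower number from compound 3 to compound 4 (0.30 log units; within the scatter). Compound 4 is estimated at 6300 nM, with a range from 1500 nM to 25000 nM.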

Compound 4, half-maximal inhibitory concentration: 12600 nM
The estimate for compound 4 lay 2.0-fold (0.30 log units) below the measured number, and the stated range covers the measured number.
By their numbers in this assay, from the lowest: compound 1; then compound 2; then compounds 3 and 4 (each within the scatter of the next).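

In this assay, cyano in place of hydrogen on the phenyl, para to a large group, gives no change at the digits printed from compound 3 to compound 4 (within the scatter), the first measured substituent on this ring, so at this position the cyano group leaves the number where it was. The gaps to the two bicyclic groups stand as before, with a 10-fold higher number from compound 2 to compound 4 (1.00 log units; beyond the scatter) and a 500-fold higher number from compound 1 to compound 4 (2.70 log units; beyond the scatter), so this addition of two heavy atoms recovers none of the ground separating the benzyl series from the naphthalen-2-yl and 1H-indol-2-yl compounds. Nothing measured here explains this result.

From the compounds shown here alone, whether an amine, a carboxylic acid or a methoxy group at the same position would also leave the number unmoved stays open. So does whether cyano would be equally silent on the 1H-indol-2-yl group of compound 1, or at another carbon of the phenyl.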